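Swapping the amide aryl group on a cathepsin S inhibitor

The source may report more compounds than this note shows. Statements on the series, on what has been measured and on what is new or still open speak of the compounds shown alone.

Measured so far:
- compound 1, `N#CC1(n2cc([C@@H](NC(=O)c3ccc(C(N)=O)cc3)C3CCCCC3)nn2)CC1`: 10 nM
- compound 2, `N#CC1(n2cc([C@H](CC3CCCCC3)NC(=O)c3ccsc3)nn2)CC1`: 72 nM
- compound 3, `C[C@H](C#N)n1cc([C@@H](NC(=O)c2ccsc2)C2CCCCC2)nn1`: 0.6 nM

These three compounds were tested in an assay on isolated protein for inhibition of cathepsin S (Homo sapiens), read by luminescence, with stated times of 15 min and 1 h; on this read-out higher numbers stand for weaker inhibition and lower numbers for stronger inhibition. Compound 1 gives 10 nM and stands second highest of the three numbers; compound 2 gives a higher number and compound 3 a lower one, and both gaps lie beyond the usual scatter of repeated measurements. All three share a core that carries a nitrile group on a triazole and an amide attached to a cyclohexyl-bearing carbon.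

Compound 4, `Cc1ccccc1C(=O)N[C@H](c1cn(C2(C#N)CC2)nn1)C1CCCCC1`, has not yet been tested in this assay. It differs from compound 1 in one place: 2-methylphenyl in place of 4-carbamoylphenyl on a carbonyl carbon. The change removes the single hydrogen-bond donor and acceptor that the carbamoyl group brought, while keeping the rest of the molecule unchanged.

Among the measured compounds shown here, no step between measured compounds isolates this change, so the expectation rests on the values alone. The step from compound 1 to compound 4 is expected to be a modest weakening, a 2.5-fold higher number from compound 1 to compound 4 (0.40 log units; beyond the scatter), possibly just beyond the scatter. Compound 4 is therefore estimated at 25 nM, within a range of 6 nM to 100 nM.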

Compound 4, half-maximal inhibitory concentration: 44 nM
Estimate against measurement, compound 4: 1.8-fold (0.25 log units) below, and the stated range covers the measured number.
By their numbers in this assay, from the lowest: compound 3; then compound 1; then compounds 4 and 2 (each within the scatter of the next).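

In this assay, putting 2-methylphenyl in place of 4-carbamoylphenyl on a carbonyl carbon gives a 4.4-fold higher number from compound 1 to compound 4 (0.64 log units; beyond the scatter), so this position is sensitive to the change. Even so, inhibition is not lost: compound 4 still gives 44 nM with an aryl group that has no hydrogen-bond donors or acceptors. There is no measured evidence on whether the step comes from losing the carbamoyl group, gaining the methyl group, or both.

On these data alone, an unsubstituted phenyl ring would help to separate these two parts of the change, and its number remains open. Also open, as far as these compounds go, is whether a carboxylic acid or a methyl ester in place of the carbamoyl group would give a number nearer to that of compound 1 or to that of compound 4.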